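Swapping a Phenylpropyl Arm for an Amide on a Piperidine

The source may hold more compounds than are shown below. What is called first, only, known or untested is meant among the compounds shown, and "the series" means these compounds.

Measured so far:
Compound 1, `O=C(OCc1ccccc1-c1ccccc1)C1CCCN(CCCc2ccccc2)C1`, gives 10200 nM in an in vitro functional assay on HEK ts201 cells for antagonist activity at Neuronal acetylcholine receptor; alpha3/beta4 (Homo sapiens), read by fluorescence and calcium flux; a lower number here means a stronger inhibitor, a higher number a weaker inhibitor.
Compound 2, `O=C(OC1CCCN(CCCc2ccccc2)C1)c1ccccc1-c1ccccc1`, gives 2700 nM in this assay.

Both compounds carry the same biphenyl ester and the same ring nitrogen bearing a 3-phenylpropyl arm; they differ in how the ester joins the ring. Of the two numbers, compound 2 has the lower one, and the gap to compound 1 is beyond the usual scatter of repeated measurements, so compound 2 is the stronger inhibitor of the two.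

Compound 3, `O=C(OC1CCCN(C(=O)CCc2ccccc2)C1)c1ccccc1-c1ccccc1`, keeps everything in compound 2 except one part: phenethylcarbonyl in place of 3-phenylpropyl on an amine nitrogen in a ring. The ring nitrogen thus no longer carries a plain chain but a carbonyl-linked chain of the same phenyl-bearing length. Among the measured compounds shown here, no pair of measured compounds covers this kind of change, so there is no measured step to lean on. The expectation is nonetheless that the step from compound 2 to compound 3 weakens inhibition, estimated at a 5.6-fold higher number from compound 2 to compound 3 (0.74 log units; beyond the scatter). Compound 3 is therefore expected to give about 15000 nM in this assay, within a range of 4000 nM to 60000 nM.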

Compound 3, half-maximal inhibitory concentration: 6000 nM
Beside the measured number, compound 3's estimate is 2.5-fold (0.40 log units) above it, and the stated range covers the measured number.
By their numbers in this assay, from the lowest: compound 2; then compounds 3 and 1 (each within the scatter of the next).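

Putting phenethylcarbonyl in place of 3-phenylpropyl on the amine nitrogen in the ring gives a 2.2-fold higher number from compound 2 to compound 3 (0.35 log units; beyond the scatter) in this assay. Among the compounds shown here, this is the first measured change at this position, and it shows that the position does respond to the change, though only modestly: the step lies beyond the scatter, yet compound 3 still gives a measurable number, so turning the plain chain into a carbonyl-linked amide does not abolish inhibition. Nothing shown here explains why the number rises, as no separate measurement bears on this step.

A single step on one core cannot say whether a benzyl group, a longer chain or a urea on this same nitrogen would give a lower or a higher number than the two groups compared here. It also leaves open whether the same swap would give a step of similar size on the core of compound 1, where the ester joins the ring differently.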